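The source may hold more compounds than are shown below. What is called first, only, known or untested is meant among the compounds shown, and "the series" means these compounds.

In a functional assay on the whole organism with Mus musculus as the target (a lower number here means that less compound is needed, a higher number that more compound is needed for the effect), compound 3 `O=C(/C=C1\CCc2ccc(F)cc21)NC1CCC1` gives only a limit, > 100 mg/kg, and not a number. Compound 1 `NC(=O)/C=C1/CCc2ccc(F)cc21` gives 64 mg/kg and compound 2 `NC(=O)/C=C1\CCc2c(F)cc(F)cc21` gives 69 mg/kg, two values within the usual scatter of each other. Compound 4 `NC(=O)/C=C1\CCc2ccc(F)cc21` differs from compound 3 by a single change, hydrogen in place of cyclobutyl on an amide-type nitrogen. Compound 1 at 64 mg/kg and compound 2 at 69 mg/kg also carry hydrogen on that nitrogen, so a modest move to a lower number is expected in this assay. The limit for compound 3 leaves the exact size of that move open. The expected change is an at least 1.6-fold lower number from compound 3 to compound 4 (0.22 log units; that floor lies within the scatter). For compound 4 the estimated value is 60 mg/kg, with an expected range from 30 mg/kg to 110 mg/kg.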

Compound 4, dose for half-maximal effect: 56 mg/kg
The estimate for compound 4 lay 1.1-fold (0.03 log units) above the measured number, and the stated range covers the measured number.
By their numbers in this assay, from the lowest: compounds 4, 1 and 2 (each within the scatter of the next). At a limit, above all of these: compound 3.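

In this assay, hydrogen in place of cyclobutyl on the amide-type nitrogen gives an at least 1.7-fold lower number from compound 3 to compound 4 (0.25 log units; that floor lies within the scatter), a floor and not a full size for the step, as it rests on a limit: the limit of > 100 mg/kg in this assay, at which 1 of the 4 values shown sits. Removing one fluoro from an aromatic carbon gives a 1.2-fold lower number from compound 2 to compound 4 (0.09 log units; within the scatter), so the extra fluoro of compound 2 leaves no readable mark here. Reversing the double bond gives a 1.1-fold lower number from compound 1 to compound 4 (0.06 log units; within the scatter), and this pair tests geometry alone: the fact that compounds 1 and 4 differ only in the configuration as drawn. As far as these compounds go, whether a methyl or a longer chain on that nitrogen would match the plain amide stays open. So does the effect of a chloro or a methoxy group on the aromatic ring.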